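Thiocarbamate Acid Dissociation: Trichloromethyl in Place of Nitro

The source may hold more compounds than are shown below. What is called first, only, known or untested is meant among the compounds shown, and "the series" means these compounds.

Compound 1 `O=[N+]([O-])c1ccc(Sc2ccc(NC(=S)Oc3ccc(O)cc3)cc2)cc1`, compound 2 `Oc1ccc(OC(=S)Nc2ccc(Sc3ccc(C(Cl)(Cl)Cl)cc3)cc2)cc1` and compound 3 `CC(=O)Nc1ccc(OC(=S)Nc2ccc(Sc3ccc([N+](=O)[O-])cc3)cc2)cc1` have been measured, while compound 4 `CC(=O)Nc1ccc(OC(=S)Nc2ccc(Sc3ccc(C(Cl)(Cl)Cl)cc3)cc2)cc1` has not. In a physicochemical assay for acid dissociation, compound 1 gives 9.21, compound 2 gives 9.22 and compound 3 gives 8.99. The change trichloromethyl in place of nitro on an aromatic carbon made a step of a number 0.01 log units higher from compound 1 to compound 2 (within the scatter). The same change, (trichloromethyl in place of nitro on an aromatic carbon), occurs twice among these compounds, and its place is described in the same words both times. The two cores differ by acetamido in place of hydroxy on an aromatic carbon, which made a step of a number 0.22 log units lower from compound 1 to compound 3 (within the scatter). Because a number 0.01 log units higher from compound 1 to compound 2 (within the scatter) lies within the scatter, the expected step is a number 0.01 log units higher from compound 3 to compound 4 (within the scatter). Compound 4 is therefore estimated to give 9, between 8.7 and 9.3, in this assay.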

Compound 4, acid dissociation constant: 9.01
Beside the measured number, compound 4's estimate is 0.01 log units below it; the measured number falls inside the stated range.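

In this assay, putting trichloromethyl in place of nitro on the core of compound 3 gave a step of a number 0.02 log units higher from compound 3 to compound 4 (within the scatter), and on the core of compound 1 the same replacement gave a number 0.01 log units higher from compound 1 to compound 2 (within the scatter), while acetamido in place of hydroxy gave a number 0.21 log units lower from compound 2 to compound 4 (within the scatter). This shows that, on these two cores, the replacement carried over with its step staying within the scatter each time. It does not show that any real shift carries over, since neither step stands beyond the scatter, and two cores cannot speak for the whole series. Nothing given here bears on why the numbers fall as they do.

On these data alone, whether an amine or a carboxylic acid in that same place would behave alike remains open. So does whether the replacement holds on cores other than these two.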